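The compounds below may be only part of what the source reports. "The series", "measured", "known", "first", "only" and "open" are said of these compounds alone.

Measured compounds in this study:

Compound 1 `COc1cccc(CNc2ncnc3c2ncn3[C@@H]2O[C@H](CO)[C@@H](O)[C@H]2O)c1OC` — in a functional assay on HOS cells (Homo sapiens) for antiproliferative activity, with a stated time of 72 h (a higher number here means a weaker inhibitor, a lower number a stronger inhibitor), compound 1 gives a limit of > 166000 nM.
Compound 2 `COc1ccc(CNc2ncnc3c2ncn3C2OC(CO)[C@@H](O)[C@H]2O)c(O)c1` — in this assay compound 2 gives a limit of > 166000 nM.
Compound 3 `COc1cc(O)cc(OC)c1CNc1ncnc2c1ncn2[C@@H]1O[C@H](CO)[C@@H](O)[C@H]1O` — in this assay compound 3 gives a limit of > 166000 nM.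

None of these three readings is a number; each is a limit of the assay. Compound 1 therefore stands nowhere in particular among the measured compounds: it sits at the same limit as the other two, and nothing separates it from them. Among the compounds with values here, the only thing the numbers show is the limit of > 166000 nM in this assay, at which 3 of the 3 values shown sit, so no step between measured compounds can be stated.

The unmeasured compound 4 `OC[C@H]1O[C@@H](n2cnc3c(NCc4ccccc4OC(F)F)ncnc32)[C@H](O)[C@@H]1O` differs from compound 1 in one place: 2-(difluoromethoxy)phenyl in place of 2,3-dimethoxyphenyl on a saturated chain carbon bound to a nitrogen on an aromatic ring. The shared core and the sugar are kept, and the change is confined to the aromatic group on the side chain.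

Within the data shown here, with no measured step available, the expectation rests on the three limits alone. Compound 4 is expected to behave like compound 1, with an expected step from compound 1 to compound 4 of a number no higher from compound 1 to compound 4 (the limit leaves the size open), that is, none beyond the scatter. The estimate for compound 4 in this assay is 166000 nM, with a range from 40000 nM to 700000 nM, and most likely the assay reports only a limit again.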

Compound 4, half-maximal inhibitory concentration: > 166000 nM
Compound 4 gave a limit, no number; the forecaster's own chance of this, stated with the estimate: 85%; the middle value lies on the limit itself.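

In this assay compound 4 gives > 166000 nM, which is a limit and not a number. No step from compound 1 to compound 4 can be read, because both compounds rest on the same limit: the limit of > 166000 nM in this assay, at which 4 of the 4 values shown sit.

The compounds shown leave open how strongly any of them acts in this assay, and whether 2-(difluoromethoxy)phenyl in place of 2,3-dimethoxyphenyl changes that at all.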